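The source may report more compounds than this note shows. Statements on the series, on what has been measured and on what is new or still open speak of the compounds shown alone.

Among the compounds with values here, in a functional assay on A549 cells (Homo sapiens) for cytotoxicity, read by MTT assay, with a stated time of 48 h (on this read-out higher numbers stand for weaker inhibition and lower numbers for stronger inhibition), compound 1 `COc1c(OCCCCN2CCNCC2)cc(O)c2c(=O)cc(-c3ccccc3)oc12` gives 1740 nM, and this is the only number available so far. The close relative compound 2 `CCCCNCCCCOc1c(O)cc(O)c2c(=O)cc(-c3ccccc3)oc12` offers no comparison, with its result given as "not determined" (no result reported). Compound 3 `COc1c(OCCCNCc2ccccc2)cc(O)c2c(=O)cc(-c3ccccc3)oc12` keeps the core of compound 1 and alters only the side chain: benzylamino in place of (piperazin-1-yl)methyl on a saturated chain carbon, three bonds along the chain from an oxygen on an aromatic ring. Within the data shown here, no measured pair shows what this swap does, so any forecast is uncertain, and only a small move towards stronger inhibition is expected. The expected change is a 1.5-fold lower number from compound 1 to compound 3 (0.16 log units; within the scatter). The estimated value for compound 3 is 1200 nM, with a likely range of 400 nM to 4000 nM.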

Compound 3, half-maximal inhibitory concentration: 1570 nM
Estimate against measurement, compound 3: 1.3-fold (0.12 log units) below, and the stated range covers the measured number.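

Replacing (piperazin-1-yl)methyl with benzylamino at this saturated chain carbon gives a 1.1-fold lower number from compound 1 to compound 3 (0.04 log units; within the scatter) in this assay. This first comparison at this position shows that the non-aromatic ring of compound 1 and the aromatic carbon ring of compound 3 give results that cannot be told apart in this test. No supporting measurement explains this match. The compounds shown leave open whether a carboxylic acid at this place, or a longer chain carrying the benzylamino group, would give a clearly different number.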